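Methylation of the ring nitrogen in the azaindole-ether series

This account rests on a few compounds, and the source may have more. Where it says the series, first, only, none or still open, it means among the compounds named here.

Compound 1 `O=C(Nc1ccc(Oc2ccnc3[nH]ccc23)c(F)c1)c1cc2cccnc2n(-c2ccccc2)c1=O` is the parent of this set, and in a functional assay on NCI-H460 cells (Homo sapiens) for antiproliferative activity, read by MTT assay, with a stated time of 72 h (on this read-out higher numbers stand for weaker inhibition and lower numbers for stronger inhibition), compound 1 gives 180 nM. Compound 2 `O=C(Nc1ccc(Oc2ccnc3[nH]ccc23)c(F)c1)c1cc2cccnc2n(-c2ccc(Br)cc2F)c1=O` carries a bromo and fluoro substituted phenyl on the core in place of the plain phenyl of compound 1; in this assay compound 2 stands at "not determined" (no result reported), so no number is available for it. Compound 3 `O=C(Nc1ccc(Oc2ccnc3[nH]ccc23)c(F)c1)c1cc2cccnc2n(-c2ccc(C(F)(F)F)cc2Cl)c1=O` likewise has no result, its entry in this assay being "not determined" (no result reported). Among the measured compounds shown here, with no pair of measured compounds differing in a single place, no step size can be read from the data.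

Compound 4 `Cn1ccc2c(Oc3ccc(NC(=O)c4cc5cccnc5n(-c5ccc(Br)cc5F)c4=O)cc3F)ccnc21` differs from compound 2 in one place: methyl in place of hydrogen on an aromatic nitrogen of a five-membered aromatic ring with one nitrogen, part of a fused system of two rings. For the measured compounds named here, nothing measured in the set speaks to this change; the only anchor is compound 1 at 180 nM. The expectation is a step in this assay beyond the scatter, toward weaker inhibition, since the hydrogen that leaves is the only donor at that position in the shared core. Compound 4 is therefore estimated at 1500 nM, within a range of 300 nM to 8000 nM.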

Compound 4, half-maximal inhibitory concentration: 3150 nM
Compound 4: the middle estimate sits 2.1-fold (0.32 log units) below what was measured, and the stated range covers the measured number.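

In this assay compound 4 gives 3150 nM, but compound 2 has no single number there, and no step can be read between the two. The compounds shown leave open what methyl in place of hydrogen on the aromatic nitrogen does on its own. No supporting data bear on this result.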